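The compounds below may be only part of what the source reports. "The series", "measured", "known", "first", "only" and "open" are said of these compounds alone.

Series notes, step from compound 2 to compound 3.

Two compounds carry numbers. Compound 1 `O=C(CSc1nnc(-c2ccncc2)n1-c1ccccc1)N/N=C/c1ccc([N+](=O)[O-])cc1` gives, in a functional assay on HCT-116 cells (Homo sapiens) for inhibition, read by MTT assay, with a stated time of 48 h (a higher number here means a weaker inhibitor, a lower number a stronger inhibitor), 10200 nM. Compound 2 `O=C(CSc1nnc(-c2ccncc2)n1-c1ccccc1)N/N=C/c1ccc(Cl)cc1` gives in this assay 5740 nM. Among the measured compounds shown here, the only measured step is a 1.8-fold lower number from compound 1 to compound 2 (0.25 log units; within the scatter). Compound 2 therefore holds the lowest of the two numbers, with compound 1 nearest, and the gap between them is within the scatter, so no order between the two is established.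

Compound 3 `O=C(CSc1nnc(-c2ccncc2)n1-c1ccccc1)N/N=C/c1ccccc1F` is not yet measured. It differs from compound 2 by 2-fluorophenyl in place of 4-chlorophenyl on a carbon with a double bond to nitrogen. For the measured compounds named here, no measured step touches either the fluorine substituent or a 2-substituted phenyl on that carbon; the single step from compound 1 to compound 2 varies the same phenyl and stays within the scatter, which is the only precedent. On that basis the step of a 1.1-fold higher number from compound 2 to compound 3 (0.05 log units; within the scatter) is expected to stay within the scatter, with no direction claimed. For compound 3 the estimate in this assay is 6500 nM, with a range from 2500 nM to 17000 nM.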

Compound 3, half-maximal inhibitory concentration: 18000 nM
Beside the measured number, compound 3's estimate is 2.8-fold (0.44 log units) below it; measured number outside the range, above it.
By their numbers in this assay, from the lowest: compounds 2, 1 and 3 (each within the scatter of the next, the first and the last beyond it).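

At the carbon with a double bond to nitrogen, the phenyl substituent now produces a separation beyond the scatter in this assay, with a 3.1-fold higher number from compound 2 to compound 3 (0.50 log units; beyond the scatter) as a modest step. The other new step, a 1.8-fold higher number from compound 1 to compound 3 (0.25 log units; within the scatter), stays within the scatter, so 2-fluorophenyl is separated from 4-chlorophenyl but not from 4-nitrophenyl, and compound 1 cannot be placed apart from either of the others. No available evidence bears on the origin of the separation between compound 2 and compound 3.

Open, as far as these compounds go, is whether the halogen or its numbered place on the phenyl carries this step, as 2-fluorophenyl and 4-chlorophenyl differ in both, and 4-fluorophenyl or 2-chlorophenyl would part the two. Also open, from the compounds shown here alone, is how this position responds to a phenyl bearing an amine or a carboxylic acid.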